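Compound 4: a chloro group on the benzyl ring

The source may report more compounds than this note shows. Statements on the series, on what has been measured and on what is new or still open speak of the compounds shown alone.

Values in a functional assay on Cortical neurone cells (Mus musculus, strain C57BL/6), read by FLIPR and calcium flux, with a stated time of 8 min; on this read-out lower numbers stand for stronger inhibition and higher numbers for weaker inhibition:
- compound 1 `O=c1cc(-c2ccc(Cl)cc2)[nH]c2nc(-c3ccccc3)nn12` gives 2350 nM
- compound 2 `Cc1ccc(Cc2nc3[nH]c(Cc4ccccc4)cc(=O)n3n2)cc1` gives 2470 nM
- compound 3 `O=c1cc(-c2ccccc2)[nH]c2nc(Cc3ccccc3)nn12` gives 1310 nM

Compound 3 stands within the usual scatter of both compound 1 and compound 2, so these numbers do not rank the three. Compound 4 `O=c1cc(-c2ccccc2)[nH]c2nc(Cc3ccc(Cl)cc3)nn12` differs from compound 3 in one place: chloro in place of hydrogen on an aromatic carbon, turning benzyl to 4-chlorobenzyl. Among the measured compounds shown here, no measured pair shows this change alone, so no step beyond the scatter is expected in this assay, and no direction can be firmly expected. The estimate means a 1.1-fold lower number from compound 3 to compound 4 (0.04 log units; within the scatter), an expected step within that scatter. Compound 4 is estimated at 1200 nM, with an expected range of 500 nM to 2900 nM.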

Compound 4, half-maximal inhibitory concentration: 1830 nM
Estimate against measurement, compound 4: 1.5-fold (0.18 log units) below, within the range that was stated.
By their numbers in this assay, from the lowest: compounds 3, 4, 1 and 2 (each within the scatter of the next).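

Among the compounds shown here, compound 3 and compound 4 give the first comparison here that differs in one place: in this assay, the change from benzyl to 4-chlorobenzyl gives a 1.4-fold higher number from compound 3 to compound 4 (0.15 log units; within the scatter). The benzyl ring of compound 3 therefore accepts a chloro group without a change that this read-out can separate from scatter. No available evidence bears on this result.

The compounds shown leave open whether an amine or a carboxylic acid in place of this chloro group would move the number beyond the scatter. They also leave open whether a chloro group on the phenyl ring of compound 3 would do so.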